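Replacing hydroxy with nitro in a two-compound series

The compounds below may be only part of what the source reports. "The series", "measured", "known", "first", "only" and "open" are said of these compounds alone.

compound 1 `COc1ccc(/C(F)=C/c2cc(OC)c(OC)c(OC)c2)cc1O` gives 26600 nM
compound 2 `COc1ccc(/C(F)=C\c2cc(OC)c(OC)c(OC)c2)cc1O` gives 4700 nM

In a functional assay on cells (Endothelial cell, Bos taurus) for antiproliferative activity (a higher number here means a weaker inhibitor, a lower number a stronger inhibitor), compound 2 holds the lower of the two numbers. Compound 3 `COc1ccc(/C(F)=C\c2cc(OC)c(OC)c(OC)c2)cc1[N+](=O)[O-]` carries nitro in place of hydroxy on an aromatic carbon ortho to a methoxy group. Within the data shown here, the only measured step of a 5.7-fold lower number from compound 1 to compound 2 (0.75 log units; beyond the scatter) is a change of configuration alone (the fact that compounds 1 and 2 differ only in the configuration as drawn) and leaves the hydroxy in place. Among the measured compounds shown here, it therefore gives a rough yardstick of size and no direct guide, and no measured step touches this substituent. On that yardstick a modest move to a higher number in this assay is expected, though the direction is uncertain. The expected step is a 2.6-fold higher number from compound 2 to compound 3 (0.41 log units; beyond the scatter) with wide uncertainty on it. For compound 3 the estimated value is 12000 nM with an expected range of 2500 nM to 50000 nM in this series.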

Compound 3, half-maximal inhibitory concentration: 329000 nM
Compound 3: the middle estimate sits 27-fold (1.44 log units) below what was measured; the measured number lies above the stated range.
By their numbers in this assay, from the lowest: compound 2; then compound 1; then compound 3.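

In this assay, the aromatic carbon ortho to a methoxy group proves highly sensitive to its substituent: nitro in place of hydroxy gives a 70-fold higher number from compound 2 to compound 3 (1.85 log units; beyond the scatter). Among these compounds, that step is printed as large, whereas the only earlier step, a 5.7-fold lower number from compound 1 to compound 2 (0.75 log units; beyond the scatter), is printed as modest, so within these three compounds the choice of substituent here outweighs the double-bond configuration. The exchange removes the hydrogen-bond donor of the hydroxy and adds heavy atoms, but no measurement shown explains the loss or separates these two changes.

On these data alone, whether an amine or a carboxylic acid on this carbon would stay close to compound 2 remains open, so hydroxy cannot yet be called a specific requirement. Also open, as far as these compounds go, is whether nitro has the same effect in the double-bond configuration of compound 1.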